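Swapping one group on a weak inhibitor

This account rests on a few compounds, and the source may have more. Where it says the series, first, only, none or still open, it means among the compounds named here.

Measured so far in a functional assay (Homo sapiens) for inhibition; a higher number here means a weaker inhibitor, a lower number a stronger inhibitor:
Compound 1 `O=C(O)/C=C/c1ccc(-c2ccc(O)c(CC3CCCCC3)c2)cc1` gives 2300 nM
Compound 2 `O=C(O)/C=C/c1ccc(-c2ccc(O)c(CC3CCCCCCCCCCC3)c2)cc1` gives "not determined" (no result reported)

Within the data shown here, compound 1 holds the only number in this small set. Its 2300 nM stands alone, and compound 2 offers no number to compare it with, so nothing yet shows how strong compound 1 is among its relatives.

Compound 3 `O=C(O)/C=C/c1ccc(-c2ccc(O)c(-c3ccccc3)c2)cc1` has phenyl in place of cyclohexylmethyl on an aromatic carbon and otherwise shares the core of compound 1. Among the measured compounds shown here, no measured pair shows what such a swap does, so any expectation here is a cautious guess. In this assay a moderate step toward a higher number, somewhat beyond the scatter, is expected, which would mean a weaker inhibitor. The estimated change is a 2.2-fold higher number from compound 1 to compound 3 (0.34 log units; beyond the scatter) as a rough guide. For compound 3 the expected value is 5000 nM with a range from 1500 nM to 20000 nM in this estimate.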

Compound 3, half-maximal inhibitory concentration: 12500 nM
For compound 3 the middle estimate is 2.5-fold (0.40 log units) below the measured one, and the stated range covers the measured number.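

In this assay, this position on an aromatic carbon, ortho to a hydroxy group, is sensitive to the group it carries: phenyl in place of cyclohexylmethyl gives a 5.4-fold higher number from compound 1 to compound 3 (0.74 log units; beyond the scatter), so compound 3 is the weaker inhibitor. The swap changes two things at once, since the non-aromatic ring becomes an aromatic one and the group goes from 7 heavy atoms to 6, with the ring now sitting directly on the aromatic carbon. Nothing available explains why this swap weakens inhibition.

Which of those two changes accounts for the loss remains open. A benzyl group, which pairs the aromatic ring with the extra carbon, or a cyclohexyl group, which pairs the non-aromatic ring with a direct attachment, would separate them.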